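Amide-nitrogen substituent exchange from compound 3 to compound 4

The compounds below may be only part of what the source reports. "The series", "measured", "known", "first", "only" and "open" are said of these compounds alone.

Of the compounds shown here, three sharing one core have been measured in an assay for inhibition of 6-phosphofructo-2-kinase/fructose-2,6-bisphosphatase 3 (Homo sapiens), read by ADP-Glo, with a stated time of 2 h; a lower number here means a stronger inhibitor, a higher number a weaker inhibitor. Compound 1 `Cn1ccc2ccc(-c3cc(Nc4ccccc4S(=O)(=O)N4CCOCC4)cc4nccnc34)cc21` gives 36 nM. Among the compounds with values here, compound 2 `Cn1cc(CNS(=O)(=O)c2ccccc2Nc2cc(-c3ccc4ccn(C)c4c3)c3nccnc3c2)cn1` gives 38 nM; the single step between neighbours, a 1.1-fold higher number from compound 1 to compound 2 (0.02 log units; within the scatter), shows that the group on the sulfonyl sulfur can be exchanged without a shift beyond the scatter. Compound 3 `Cn1cc(NC(=O)c2ccncc2Nc2cc(-c3ccc4ccn(C)c4c3)c3nccnc3c2)cn1` gives 33 nM, the lowest of the three numbers, yet its gaps to compound 1 and to compound 2 both lie within the scatter, so no order among the three can be read from these figures.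

Compound 4 `CN1CCC(CNC(=O)c2ccncc2Nc2cc(-c3ccc4ccn(C)c4c3)c3nccnc3c2)C1` differs from compound 3 in one place: (1-methylpyrrolidin-3-yl)methyl in place of 1-methyl-1H-pyrazol-4-yl on an amide-type nitrogen. Within the data shown here, no measured step touches the amide-type nitrogen, and none exchanges an aromatic ring for a non-aromatic one; the one available step, on the sulfonyl sulfur, stayed within the scatter. The expectation is therefore a number close to that of compound 3, with wide uncertainty. The expected step of a 1.2-fold higher number from compound 3 to compound 4 (0.08 log units; within the scatter) is small. Compound 4 is estimated at 40 nM, with a range from 15 nM to 110 nM.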

Compound 4, half-maximal inhibitory concentration: 74 nM
Beside the measured number, compound 4's estimate is 1.9-fold (0.27 log units) below it, within the range that was stated.
By their numbers in this assay, from the lowest: compounds 3, 1, 2 and 4 (each within the scatter of the next, the first and the last beyond it).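

In this assay, within the data shown here, the amide-type nitrogen gives the first exchange that moves the number beyond the scatter: a 2.2-fold higher number from compound 3 to compound 4 (0.35 log units; beyond the scatter). Among these compounds, the substituent here is therefore not interchangeable in the way the group on the sulfonyl sulfur was in the one earlier step, although the shift remains modest and only this single pair supports it. Nothing measured in these data bears on the origin of the shift.

The exchange alters two features together, replacing the five-membered aromatic ring with a non-aromatic one and placing a methyl-derived link between ring and nitrogen, so the compounds shown do not separate these contributions. Open, as far as these compounds go, is where 1-methylpyrrolidin-3-yl attached directly to the amide-type nitrogen, or (1-methyl-1H-pyrazol-4-yl)methyl on that nitrogen, would fall relative to compound 3 and compound 4.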